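Iodo for Bromo on Two Related Anti-Inflammatory Cores

This account rests on a few compounds, and the source may have more. Where it says the series, first, only, none or still open, it means among the compounds named here.

Compound 1 `Brc1ccc2nc(-c3ccccc3)nc(N3CCC(c4ccccc4)CC3)c2c1` and compound 2 `Ic1ccc2nc(-c3ccccc3)nc(N3CCC(c4ccccc4)CC3)c2c1` share one core and differ only in one substituent: iodo in place of bromo on an aromatic carbon. In a functional assay on the whole organism for inhibition, with Rattus norvegicus as the target, read by paw edema, with stated times of 4 days, 1 h and 2 h, at a dose of 100 mg/kg by the oral route (on this read-out higher numbers stand for more inhibition at the one dose given (going by the name of the read-out) and lower numbers for less inhibition), compound 1 gives 57.6%, and compound 2 gives 82.5%, a step of a number 24.9 percentage points higher from compound 1 to compound 2 (beyond the scatter). Compound 3 `CC1CCN(c2nc(-c3ccc(Cl)cc3)nc3ccc(Br)cc23)CC1` rests on a different core; how its core differs from that of compound 1 is not broken down here. In this assay compound 3 gives 55.1%, a number within the scatter of compound 1. Compound 4 `CC1CCN(c2nc(-c3ccc(Cl)cc3)nc3ccc(I)cc23)CC1` carries the same change on the core of compound 3: iodo in place of bromo on an aromatic carbon. The two places are described word for word alike, so this is the same change. Compound 4 is therefore expected to step up from compound 3 by a number 19.9 percentage points higher from compound 3 to compound 4 (beyond the scatter), resting on a number 24.9 percentage points higher from compound 1 to compound 2 (beyond the scatter). The value of compound 4 in this assay is expected to be near 75%, between 58% and 90%.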

Compound 4, a percentage reported as inhibition, in the whole organism at one dose (the size of the read-out at that dose, not a potency): 45.8%
Beside the measured number, compound 4's estimate is 29.2 percentage points above it; measured number outside the range, below it.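

In this assay, iodo in place of bromo gives a number 9.3 percentage points lower from compound 3 to compound 4 (within the scatter), so the rise seen on the core of compound 1 does not reappear on the core of compound 3. The effect of this change therefore does not carry over from one core to the other, and the two steps differ: the same change on two cores in this assay, a number 24.9 percentage points higher (beyond the scatter) from compound 1 to compound 2 and a number 9.3 percentage points lower (within the scatter) from compound 3 to compound 4, 34.2 percentage points apart, beyond the scatter of two such steps. Going by these compounds alone, with only two pairs, this does not show which difference between the cores matters, or how the change would behave on any further core.

From the compounds shown here alone, only bromo and iodo appear at this aromatic carbon, so it remains open how a group such as an amine or a carboxylic acid would read there on either core. Going by these compounds, whether the gap between the two steps would hold at other doses also remains open.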